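A 3-(trifluoromethyl)phenyl group on the double-bonded nitrogen

The source may hold more compounds than are shown below. What is called first, only, known or untested is meant among the compounds shown, and "the series" means these compounds.

In a functional assay on HCT-116 cells (Homo sapiens) for cytotoxicity, read by sulforhodamine B assay, with a stated time of 24 h (a higher number here means a weaker inhibitor, a lower number a stronger inhibitor), compound 1 `N#CCC(=O)N/N=C1\C(=O)Nc2ccc(S(=O)(=O)N3CCOCC3)cc21` gives 10300 nM and holds the lowest of three numbers (compound 2 `Cc1ccc(/N=C2\C(=O)Nc3ccc(S(=O)(=O)N4CCOCC4)cc32)cc1` gives 18900 nM and compound 3 `O=C1Nc2ccc(S(=O)(=O)N3CCOCC3)cc2/C1=N/c1ccc(O)cc1` gives 27300 nM). Compound 4 `O=C1Nc2ccc(S(=O)(=O)N3CCOCC3)cc2/C1=N/c1cccc(C(F)(F)F)c1` puts 3-(trifluoromethyl)phenyl in place of ((cyanomethyl)carbonyl)amino on a double-bonded nitrogen. Two measured exchanges of that group for a substituted phenyl bear on this change (a 1.8-fold higher number from compound 1 to compound 2 (0.26 log units; within the scatter); a 2.7-fold higher number from compound 1 to compound 3 (0.42 log units; beyond the scatter)). The phenyl substituent itself mattered little (a 1.4-fold higher number from compound 2 to compound 3 (0.16 log units; within the scatter)). In this assay the expected step for compound 4 is a 1.9-fold higher number from compound 1 to compound 4 (0.29 log units; within the scatter) and points upward, close to the edge of the scatter. Compound 4 is estimated at 20000 nM (expected range 9000 nM to 45000 nM).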

Compound 4, half-maximal inhibitory concentration: 15900 nM
Compound 4: the middle estimate sits 1.3-fold (0.10 log units) above what was measured; measured number inside the range.
By their numbers in this assay, from the lowest: compounds 1, 4, 2 and 3 (each within the scatter of the next, the first and the last beyond it).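

In this assay, a phenyl group bearing 3-(trifluoromethyl), with no hydrogen-bond donors or acceptors, stays within the scatter of the ((cyanomethyl)carbonyl)amino group it replaces (a 1.5-fold higher number from compound 1 to compound 4 (0.19 log units; within the scatter)). It also stays within the scatter of both earlier phenyl compounds (a 1.7-fold lower number from compound 3 to compound 4 (0.23 log units; within the scatter)) and (a 1.2-fold lower number from compound 2 to compound 4 (0.08 log units; within the scatter)), so a third kind of substituted phenyl on the double-bonded nitrogen leaves the number essentially unmoved. Nothing measured here explains this insensitivity.

The compounds shown leave open whether an amine or a carboxylic acid on the phenyl ring would move the number beyond the scatter. The same question stands for a longer chain in place of the phenyl ring.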